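The compounds below may be only part of what the source reports. "The series", "measured", "known", "first", "only" and "open" are said of these compounds alone.

Compounds measured so far in a physicochemical assay, read by spectrophotometry, with a stated time of 25 min; a higher number here means a weaker inhibitor, a lower number a stronger inhibitor:
compound 1, `O=c1cc(-c2ccccc2)oc2cc(OCCCCNc3nc4c(F)cc(F)cc4s3)cc(O)c12`, 15.1 ug/mL
compound 2, `O=C(O)c1ccc2nc(NCCCCOc3cc(O)c4c(=O)cc(-c5ccccc5)oc4c3)sc2c1`, 21.7 ug/mL

Compound 2 gives the higher of the two numbers, the weaker inhibition, though its gap to compound 1 is small: a 1.4-fold higher number from compound 1 to compound 2 (0.16 log units; within the scatter), a step that does not rise above the scatter of repeated runs. The only structural move between the two measured compounds is this exchange of one 1,3-benzothiazol-2-yl group for another on the amine nitrogen, and it left the read-out essentially unchanged.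

Compound 3, `O=c1cc(-c2ccccc2)oc2cc(OCCCCNNc3nc4ccccc4s3)cc(O)c12`, carries the change ((1,3-benzothiazol-2-yl)amino in place of 6-carboxy-1,3-benzothiazol-2-yl on an amine nitrogen). Going by the values given here, the one measured step that bears on it is the exchange from compound 1 to compound 2, which stayed within the scatter; that step touched the same part of the molecule, though it did not change the linker in the way the move to compound 3 does. Among the compounds with values here, with no step pointing clearly either way, compound 3 is expected to land close to compound 2 in this assay, a 1.2-fold lower number from compound 2 to compound 3 (0.08 log units; within the scatter), and no change beyond the scatter is anticipated. Compound 3 is therefore estimated at 18 ug/mL, with a plausible range from 8 ug/mL to 40 ug/mL.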

Compound 3, half-maximal inhibitory concentration: 24.3 ug/mL
Estimate against measurement, compound 3: 1.4-fold (0.13 log units) below; the range from low to high includes it.
By their numbers in this assay, from the lowest: compounds 1, 2 and 3 (each within the scatter of the next).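

In this assay, putting (1,3-benzothiazol-2-yl)amino in place of 6-carboxy-1,3-benzothiazol-2-yl on the amine nitrogen gives a 1.1-fold higher number from compound 2 to compound 3 (0.05 log units; within the scatter), and putting it in place of 4,6-difluoro-1,3-benzothiazol-2-yl gives a 1.6-fold higher number from compound 1 to compound 3 (0.21 log units; within the scatter). The earlier pair covered only an exchange of one substituted 1,3-benzothiazol-2-yl group for another, whereas these steps show that the read-out also stays within the scatter when the group entering at this place carries an additional nitrogen and no carboxy or fluoro substituent. Nothing available explains why the three numbers lie so close together.

Since every step shown lies within the scatter, the compounds leave open whether any group on this amine nitrogen can shift the number beyond it, for instance a simple alkyl amine or a phenyl ring bearing a carboxylic acid in place of the 1,3-benzothiazol-2-yl group. They also leave open what a longer chain in place of the saturated chain on that nitrogen would do in this assay.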